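Swapping the anilide ring on a thiazolidinedione naphthyl ether

The source may report more compounds than this note shows. Statements on the series, on what has been measured and on what is new or still open speak of the compounds shown alone.

Measured so far:
- compound 1, `CCOc1ccc2nc(NC(=O)COc3ccc4cc(/C=C5/SC(=O)NC5=O)ccc4c3)sc2c1`: 17000 nM
- compound 2, `COc1cccc(NC(=O)COc2ccc3cc(/C=C4/SC(=O)NC4=O)ccc3c2)c1`: 7600 nM
- compound 3, `O=C(COc1ccc2cc(/C=C3/SC(=O)NC3=O)ccc2c1)Nc1ccccn1`: > 50000 nM

Three compounds share one core and differ only in the group attached to the amide-type nitrogen. In an assay on isolated protein for inhibition of histone deacetylase 8 (Homo sapiens), with a stated time of 1 h (on this read-out lower numbers stand for stronger inhibition and higher numbers for weaker inhibition), compound 2 gives 7600 nM, the lowest of the two numbers shown. Among the compounds with values here, compound 1 sits next, and since no single-point step between it and compound 2 is computed, only the two values speak: compound 1 gives 17000 nM. Compound 3 reaches only a limit of this assay, > 50000 nM, which corresponds to the limit of > 50000 nM in this assay, at which 1 of the 3 values shown sits.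

Within the data shown here, the one measured step with a number, an at least 6.5-fold higher number from compound 2 to compound 3 (0.81 log units; beyond the scatter), shows that replacing the aromatic carbon ring by a pyridin-2-yl costs potency. Compound 4, `O=C(COc1ccc2cc(/C=C3/SC(=O)NC3=O)ccc2c1)Nc1ccc(F)cc1F`, takes a different route: 2,4-difluorophenyl in place of 3-methoxyphenyl on an amide-type nitrogen. The ring stays a carbon-only aromatic ring, as in compound 2, so the large loss seen for compound 3 is not expected to repeat. The change from compound 2 to compound 1 suggests that the exact ring substituent shifts the number only moderately.

The expected result is therefore a small step, a 1.3-fold higher number from compound 2 to compound 4 (0.12 log units; within the scatter), at most modestly weaker. Compound 4 is estimated at 10000 nM, with a range from 4000 nM to 30000 nM.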

Compound 4, half-maximal inhibitory concentration: > 50000 nM
Compound 4: only a limit was reported; the forecaster's own chance of this, stated with the estimate: 15%; middle value at least 5.0-fold (0.69 log units) away from the limit.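

In this assay compound 4 gives > 50000 nM, and this value is a limit of the assay, not a number. Keeping a ring of carbon only does not hold the activity at this position, as 2,4-difluorophenyl in place of 3-methoxyphenyl on the amide-type nitrogen gives an at least 6.5-fold higher number from compound 2 to compound 4 (0.81 log units; beyond the scatter), so the loss is no longer confined to the pyridin-2-yl group of compound 3. Compound 3 and compound 4 now stop at the same limit, which means the step between them cannot be read and neither replacement can be ranked against the other: the limit of > 50000 nM in this assay, at which 2 of the 4 values shown sit.

The compounds shown leave open whether the methoxy group of compound 2 itself matters or whether the fluorine atoms of compound 4 do the harm, a question that an unsubstituted phenyl ring, or a phenyl ring carrying a hydroxyl group or an amine in place of methoxy, could help to separate. From the compounds shown here alone, how far compound 3 and compound 4 lie beyond the limit also remains unknown.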